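A few compounds are considered here, and "the series" means these few. Any claim that something is new, unique, unknown or untested is made for them only; others in the source may bear on it.

Measured compounds:
- Compound 1, `C[C@@H]1CN(C(=O)c2nc(Nc3cc(C4CC4)[nH]n3)c3cc(Cl)ccc3n2)CCN1C(=O)OC(C)(C)C`, in an ADME assay on S9 fraction from liver (Rattus norvegicus), read by LC-MS, with a stated time of 60 min, at 37 degrees C (a higher number here means that more of the compound is left, a lower number that less of the compound is left), gives 71.3%.
- Compound 2, `C[C@@H]1CN(C(=O)c2nc(Nc3cc(C4CC4)[nH]n3)c3cc(Cl)ccc3n2)CCN1C(=O)OCC(Cl)(Cl)Cl`, in this assay gives 78.9%.

Compound 2 stands at the higher of the two numbers, but only by a small margin: a number 7.6 percentage points higher from compound 1 to compound 2 (within the scatter). The two compounds therefore cannot be told apart on this read-out.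

Compound 3, `C[C@@H]1CN(C(=O)c2nc(Nc3cc(C4CC4)[nH]n3)c3cc(Cl)ccc3n2)CCN1C(=O)OCOC(=O)C(C)(C)C`, has not been measured. It differs from compound 2 in one place: ((tert-butyl)carbonyl)oxy in place of trichloromethyl on a saturated chain carbon bound to an oxygen next to a carbonyl group. The carbamate itself, the piperazine ring and the shared core stay as they are.

Within the data shown here, only one measured step bears on this change, and it is the swap between compound 1 and compound 2 at the same position, which stayed within the scatter. That step exchanged one hydrocarbon-like group for a chlorinated one; the present change instead brings in a group with a carbonyl and two oxygen atoms, so the earlier step is only a loose guide. On that basis compound 3 is expected to give 65%, with a range from 35% to 85%, and the estimated step of a number 13.9 percentage points lower from compound 2 to compound 3 (beyond the scatter) is not expected to reach beyond the scatter, though the range is kept wide to allow for the less similar group.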

Compound 3, percent of the compound remaining: 47%
Compound 3: middle estimate off by 18 percentage points, on the high side; the range from low to high includes it.
By their numbers in this assay, from the lowest: compound 3; then compounds 1 and 2 (each within the scatter of the next).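

At this position, on an oxygen next to a carbonyl group, the group can clearly change the outcome: in this assay the swap gives a number 31.9 percentage points lower from compound 2 to compound 3 (beyond the scatter) and the second comparison gives a number 24.3 percentage points lower from compound 1 to compound 3 (beyond the scatter) for the same new group. Tert-butyl and 2,2,2-trichloroethyl stay within the scatter of each other, so among these three compounds only (((tert-butyl)carbonyl)oxy)methyl separates from the others. The entering group carries hydrogen-bond acceptors and a double bond outside aromatic rings, which trichloromethyl lacks, but nothing available here connects the lower number to either of these features or gives a reason for it.

From the compounds shown here alone, what stays open is which part of the new group goes with the lower number: (acetyloxy)methyl, with methyl in place of the tert-butyl, would test the far end of the group, while methoxymethyl would test the need for its carbonyl. Going by these compounds, it also stays open how a simple ethyl group would read on the same oxygen, and whether it would fall with the first two compounds or with compound 3.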